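Oxopiperazinyl in Place of Oxanyl on the Phenylbutyl Carbamoyl Core

The compounds below may be only part of what the source reports. "The series", "measured", "known", "first", "only" and "open" are said of these compounds alone.

Compound 1 `CC(C)CNC(=O)n1c(=O)oc2ccc(C3CCN(C)CC3)cc21`: 295 nM
Compound 2 `O=C(NCCCCc1ccccc1)n1c(=O)oc2cc(C3CCOCC3)ccc21`: 68 nM
Compound 3 `O=C(NCCCCc1ccccc1)n1c2c(oc1=O)CCN(Cc1ccccc1)C2`: 436 nM

Of the compounds shown here, three have been measured in an assay on HEK293 cells for inhibition of acid ceramidase (Homo sapiens), read by fluorescence, with stated times of 10 min and 3 h; on this read-out lower numbers stand for stronger inhibition and higher numbers for weaker inhibition. Compound 2 gives the lowest number of the three, 68 nM, and its distance to both compound 1 and compound 3 lies beyond the usual scatter, so among these three it is the most potent. Compound 1, with a different amide substituent and a different ring on the aromatic carbon, gives 295 nM, and compound 3, with a different core, gives 436 nM.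

Compound 4 `CN1CCN(c2ccc3c(c2)oc(=O)n3C(=O)NCCCCc2ccccc2)C(=O)C1` has not yet been measured in this assay. It differs from compound 2 in one place: 4-methyl-2-oxopiperazin-1-yl in place of oxan-4-yl on an aromatic carbon. Going by the values given here, no pair of measured compounds shows this change or a related one, so the size of its effect can only be guessed. The step from compound 2 to compound 4 is expected to be a modest weakening, a 1.9-fold higher number from compound 2 to compound 4 (0.28 log units; within the scatter), perhaps just beyond the scatter. Compound 4 is therefore estimated at 130 nM, within a range from 40 nM to 420 nM.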

Compound 4, half-maximal inhibitory concentration: 52 nM
Beside the measured number, compound 4's estimate is 2.5-fold (0.40 log units) above it; the range from low to high includes it.
By their numbers in this assay, from the lowest: compounds 4 and 2 (each within the scatter of the next); then compounds 1 and 3 (each within the scatter of the next).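

In this assay, exchanging oxan-4-yl for 4-methyl-2-oxopiperazin-1-yl on this aromatic carbon gives a 1.3-fold lower number from compound 2 to compound 4 (0.12 log units; within the scatter) and so leaves the read-out where it was. The earlier compounds shown here offered no single-place comparison, and this pair shows that this carbon accepts a group with more heavy atoms, a second ring hetero atom and an additional hydrogen-bond acceptor without a measurable loss. Nothing available explains why the two groups read alike.

As far as these compounds go, it remains open whether a 2-oxopiperazin-1-yl group without the methyl, or a piperazin-1-yl ring without the carbonyl, would read the same here. Also open, from the compounds shown here alone, is whether this carbon would accept an open-chain amine or a carboxylic acid equally well.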